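This account rests on a few compounds, and the source may have more. Where it says the series, first, only, none or still open, it means among the compounds named here.

Of the compounds shown here, two share one core and have been measured so far. In a functional assay on A-431 cells (Homo sapiens) for cytotoxicity (on this read-out lower numbers stand for an effect already at smaller amounts and higher numbers for an effect only at larger amounts of compound), compound 2 `COC1=C(C)C(=O)/C(=C(O)/C=C/c2cccs2)C(=O)C1(C)C` gives 10.8 ug/mL, and compound 1 `COC1=C(C)C(=O)/C(=C(O)/C=C/c2ccco2)C(=O)C1(C)C` gives 14.7 ug/mL. For the measured compounds named here, compound 2 therefore stands level with its only neighbour on these numbers, and neither compound stands apart from the other. The next compound, compound 3 `COC1=C(C)C(=O)/C(=C(O)/C=C/c2nccs2)C(=O)C1(C)C`, keeps the core and the chain of compound 2 but carries 1,3-thiazol-2-yl in place of thiophen-2-yl on a double-bonded chain carbon bound to a double-bonded chain carbon. Going by the values given here, only one measured step bears on this change, the exchange of furan-2-yl for thiophen-2-yl at the same place, which amounts to a 1.4-fold lower number from compound 1 to compound 2 (0.13 log units; within the scatter). Among the compounds with values here, no measured compound yet carries 1,3-thiazol-2-yl, so the expectation rests on that single small step between related five-membered aromatic rings. No shift beyond the scatter is expected in this assay, and no direction can be favoured. The expected change is a 1.1-fold higher number from compound 2 to compound 3 (0.05 log units; within the scatter). For compound 3 the estimated value is 12 ug/mL, with an expected range from 5.5 ug/mL to 26 ug/mL.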

Compound 3, concentration for half-maximal effect: 6 ug/mL
Compound 3: middle estimate off by 2.0-fold (0.30 log units), on the high side; low and high end bracket the measured number.
By their numbers in this assay, from the lowest: compounds 3, 2 and 1 (each within the scatter of the next, the first and the last beyond it).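

At this place, on a double-bonded chain carbon bound to a double-bonded chain carbon, a five-membered aromatic ring with 2 hetero atoms is accepted in this assay as well as one with 1 hetero atom: the exchange of thiophen-2-yl for 1,3-thiazol-2-yl gives a 1.8-fold lower number from compound 2 to compound 3 (0.26 log units; within the scatter). For the compounds shown here, the exchange of furan-2-yl for 1,3-thiazol-2-yl gives the first step at this position to pass the usual scatter, though only modestly, at a 2.5-fold lower number from compound 1 to compound 3 (0.39 log units; beyond the scatter), so the choice of ring can register on this read-out even though neither single step among the neighbouring rings settles an order with compound 2. No supporting data accompany these numbers to account for this difference.

The compounds shown leave open whether a six-membered aromatic ring such as phenyl or pyridin-2-yl, or a 1,3-thiazol-2-yl ring carrying a methyl or an amine, would hold this level in this assay. They also leave open whether the step to 1,3-thiazol-2-yl would persist with a longer chain in place of the ethenyl link.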